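Fluoro for hydrogen on the aromatic ring of compound 3

A few compounds are considered here, and "the series" means these few. Any claim that something is new, unique, unknown or untested is made for them only; others in the source may bear on it.

Measured so far in a functional assay on HeLa cells (Homo sapiens) for inhibition, read by sulforhodamine B assay, with a stated time of 48 h; a higher number here means a weaker inhibitor of growth, a lower number a stronger inhibitor of growth:
compound 1, `CC(=O)OC/C(=C\c1ccc(F)cc1)C(=O)c1ccccc1`, 25000 nM
compound 2, `CC(=O)OC/C(=C\c1ccc(Cl)cc1)C(=O)c1ccc(Cl)cc1`, 19000 nM
compound 3, `C=C(C/C(=C\c1ccccc1)C(=O)c1ccccc1)C(=O)c1ccccc1`, 19000 nM

Compound 3 stands level with compound 2 at the digits shown, the two together giving the lowest numbers of the three; the gap to compound 1 lies within the scatter, so no ranking among the three is claimed.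

Compound 4, `C=C(C/C(=C\c1ccccc1F)C(=O)c1ccccc1)C(=O)c1ccccc1`, differs from compound 3 by fluoro in place of hydrogen on an aromatic carbon. Going by the values given here, no measured pair in this set carries the same change, so there is no step to lean on. The expectation is for no movement beyond the scatter, with the step of no change at the digits printed from compound 3 to compound 4 (within the scatter) estimated as essentially nil. In this assay compound 4 is estimated at 19000 nM, with a range from 9000 nM to 40000 nM.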

Compound 4, concentration for 50% growth inhibition: 20000 nM
Beside the measured number, compound 4's estimate is 1.1-fold (0.02 log units) below it; low and high end bracket the measured number.
By their numbers in this assay, from the lowest: compounds 2, 3, 4 and 1 (each within the scatter of the next).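

Phenyl to 2-fluorophenyl gives the series its first comparison at a single place: in this assay the step is a 1.1-fold higher number from compound 3 to compound 4 (0.02 log units; within the scatter), so the two compounds stand level. Fluoro on this aromatic carbon, ortho to a large group, is tolerated in this one pair, with neither gain nor loss. No supporting measurement bears on this result.

From the compounds shown here alone, whether an amine, a carboxylic acid or a methoxy group at this carbon would also keep the number level remains open. So does whether fluoro elsewhere on the shared core would read the same.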